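Piperidinyl for isopropylamino: expected microsomal half-life

A few compounds are considered here, and "the series" means these few. Any claim that something is new, unique, unknown or untested is made for them only; others in the source may bear on it.

Measured in an in vitro ADME assay on microsomes from liver (Homo sapiens) for metabolic stability, read by LC-MS, tested at 1 uM; on this read-out lower numbers stand for a shorter-lived compound and higher numbers for a longer-lived compound:
Compound 1, `CC(C)(C)n1ccnc1/N=C(\N)Nc1ccc(Cl)c(Cl)c1`, gives > 1 h, which is a limit of the assay.
Compound 2, `CC(C)N1CCN=C1/N=C(\N)Nc1ccc(Cl)c(Cl)c1`, gives > 1 h, which is a limit of the assay.
Compound 3, `CC(C)N/C(=N\C1=NCCN1C(C)C)Nc1ccc(Cl)c(Cl)c1`, gives 0.845 h.

For the measured compounds named here, compound 3 therefore holds the only actual number among the three; the other two values sit at the limit of > 1 h in this assay, at which 2 of the 3 values shown sit. Going by the values given here, the one measured step that bears on the change ahead is an at least 1.1-fold lower number from compound 2 to compound 3 (0.07 log units; that floor lies within the scatter), and it stays within the scatter. Compound 4, `CC(C)N1CCN=C1/N=C(/Nc1ccc(Cl)c(Cl)c1)N1CCCCC1`, differs from compound 3 by piperidin-1-yl in place of isopropylamino on a carbon with a double bond to nitrogen. Since the earlier alkylation on nitrogen moved the half-life little, no step beyond the scatter is expected in this assay, with a slight lean toward a shorter-lived compound. For compound 4 the estimate is 0.7 h, within 0.35 h to 1.4 h, an expected step of a 1.2-fold lower number from compound 3 to compound 4 (0.08 log units; within the scatter).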

Compound 4, half-life: > 1 h
Compound 4: only a limit was reported (the forecaster's own chance of this, stated with the estimate: 20%); at least 1.4-fold (0.15 log units) between middle value and limit.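

In this assay compound 4 gives > 1 h as a limit of the assay. Piperidin-1-yl in place of isopropylamino on this carbon goes with an at least 1.1-fold higher number from compound 3 to compound 4 (0.07 log units; that floor lies within the scatter) and so shows that the ring, which carries no hydrogen-bond donor, brings no detectable loss of half-life here. The step from compound 2 to compound 4 cannot be read, and the values crowd at one end: the limit of > 1 h in this assay, at which 3 of the 4 values shown sit.

From the compounds shown here alone, how far the half-life of compound 4 lies beyond its limit stays open. So does whether morpholine or pyrrolidine on this carbon would match piperidin-1-yl.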